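Series notes: nitrile in place of fluorine on the aryl ring

The compounds below may be only part of what the source reports. "The series", "measured", "known", "first", "only" and "open" are said of these compounds alone.

Among the compounds with values here, compound 2 `Cc1nn(C)c2c1C(c1cccc(F)c1)=NCCN2` stands at the high end of the numbers measured so far. In a functional assay on the whole organism for positive allosteric modulation, with Rattus norvegicus as the target (a lower number here means that less compound is needed, a higher number that more compound is needed for the effect), compound 2 gives 2.5 mg/kg. Compound 3 `CCc1nn(C)c2c1C(c1cccc(F)c1)=NCCN2` gives 2.5 mg/kg, and the step of no change at the digits printed from compound 2 to compound 3 (within the scatter) keeps the two level. Compound 1 `Cc1nn(C)c2c1C(c1cccc(Cl)c1)=NCCN2` gives 0.63 mg/kg, the lowest of the three, and the step of a 4.0-fold higher number from compound 1 to compound 2 (0.60 log units; beyond the scatter) is beyond the scatter.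

The next compound is compound 4 `Cc1nn(C)c2c1C(c1cccc(C#N)c1)=NCCN2`. Its change from compound 2 is cyano in place of fluoro on an aromatic carbon, at the place on an aromatic carbon of a six-membered aromatic ring of carbon only, meta to a large group, which is also where compound 1 and compound 2 differ.

Within the data shown here, only one measured step touches that place, the step of a 4.0-fold higher number from compound 1 to compound 2 (0.60 log units; beyond the scatter), and it was modest. The step of no change at the digits printed from compound 2 to compound 3 (within the scatter) concerns another part of the core and says nothing about this position. Among the measured compounds shown here, no measured compound carries a cyano group, so the direction of the new step is open.

Compound 4 is therefore expected near compound 2 in this assay, at an estimated 2 mg/kg with a range from 0.6 mg/kg to 6.3 mg/kg. The expected step of a 1.3-fold lower number from compound 2 to compound 4 (0.10 log units; within the scatter) is small, with wide uncertainty in either direction.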

Compound 4, minimum effective dose: 1.25 mg/kg
For compound 4 the middle estimate is 1.6-fold (0.20 log units) above the measured one; low and high end bracket the measured number.
By their numbers in this assay, from the lowest: compounds 1, 4, 2 and 3 (each within the scatter of the next, the first and the last beyond it).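

Cyano in place of fluoro gives a 2.0-fold lower number from compound 2 to compound 4 (0.30 log units; within the scatter), and cyano in place of chloro gives a 2.0-fold higher number from compound 1 to compound 4 (0.30 log units; within the scatter). Within the data shown here, this place on the aromatic carbon therefore takes a group of two heavy atoms with one hydrogen-bond acceptor while the number in this assay stays within the scatter of both halogen compounds, and the only step here that lies beyond the scatter remains a 4.0-fold higher number from compound 1 to compound 2 (0.60 log units; beyond the scatter). No measurement at hand accounts for these numbers or links them to any property of the three groups.

On these data alone, how a methoxy group, a trifluoromethyl group, an amine or a carboxylic acid at this place would read in this assay stays open, so the three compounds that differ here give no trend across groups. Also open, as far as these compounds go, is whether the nitrile behaves the same way on the core of compound 3, since the methyl in place of hydrogen that separates compound 3 from compound 2 has been read only with fluoro on the aromatic ring.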